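Swapping the ring on the piperazine nitrogen once more

The source may report more compounds than this note shows. Statements on the series, on what has been measured and on what is new or still open speak of the compounds shown alone.

Of the compounds shown here, three built on one shared core have been measured so far. Compound 1 `CCN1CCN(CC(=O)Nc2nc3ccccc3[nH]2)CC1` carries an ethyl group on the ring nitrogen; in a functional assay, read by spectrophotometry, with a stated time of 30 min, tested at 150 ug/mL (on this read-out higher numbers stand for a stronger effect at the one concentration tested and lower numbers for a weaker effect), compound 1 gives 57.5%. Compound 2 `O=C(CN1CCN(c2ccccc2)CC1)Nc1nc2ccccc2[nH]1` has a phenyl in that place, and in this assay compound 2 gives 40.6%. Compound 3 `O=C(CN1CCN(c2ncccn2)CC1)Nc1nc2ccccc2[nH]1` carries a pyrimidin-2-yl there, and in this assay compound 3 gives 68.4%, the highest of the three numbers. The steps between them are all modest but beyond the scatter: a number 16.9 percentage points lower from compound 1 to compound 2 (beyond the scatter), a number 10.9 percentage points higher from compound 1 to compound 3 (beyond the scatter) and a number 27.8 percentage points higher from compound 2 to compound 3 (beyond the scatter).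

Compound 4 `COc1ccc(N2CCN(CC(=O)Nc3nc4ccccc4[nH]3)CC2)cc1` is not yet measured. It differs from compound 3 in one place: 4-methoxyphenyl in place of pyrimidin-2-yl on an amine nitrogen in a ring. Among the measured compounds shown here, the step that bears most directly on this change is the one from compound 2 to compound 3, where a carbon-only aromatic ring was replaced by the pyrimidin-2-yl and the activity rose. Compound 4 moves back toward a carbon-only ring, now with a methoxy group added, so a drop is expected, roughly toward the level of compound 2. The estimated step is a number 22.4 percentage points lower from compound 3 to compound 4 (beyond the scatter). For compound 4 the expected value in this assay is 46%, with a range from 32% to 62%.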

Compound 4, a percentage reported as activity, at one concentration (the size of the read-out at that concentration, not a potency): 53.2%
Beside the measured number, compound 4's estimate is 7.2 percentage points below it; the measured number falls inside the stated range.
By their numbers in this assay, from the lowest: compound 2; then compounds 4 and 1 (each within the scatter of the next); then compound 3.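

In this assay a carbon-only aromatic ring on this amine nitrogen turns out not to be tied to the level of plain phenyl: methoxy in place of hydrogen on an aromatic carbon gives a number 12.6 percentage points higher from compound 2 to compound 4 (beyond the scatter) and is the first change shown on that ring itself rather than a swap of the whole group. Even so, the pyrimidin-2-yl keeps its lead over the substituted ring, with a number 15.2 percentage points lower from compound 3 to compound 4 (beyond the scatter) as the step when 4-methoxyphenyl enters. Set against the ethyl group, the same 4-methoxyphenyl gives a number 4.3 percentage points lower from compound 1 to compound 4 (within the scatter) and so cannot be told apart from ethyl on this read-out, even though one group is a small chain and the other an aromatic ring.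

Nothing available here explains why either the methoxy group or the pyrimidin-2-yl moves the number.

Still open, as far as these compounds go, is whether a ring with one nitrogen, such as pyridin-2-yl, would read closer to phenyl or to pyrimidin-2-yl. Also open, from the compounds shown here alone, is whether a hydroxy group or a chlorine in place of the methoxy would raise the number over phenyl too, and how a longer chain in place of ethyl would read.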